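A few compounds are considered here, and "the series" means these few. Any claim that something is new, unique, unknown or untested is made for them only; others in the source may bear on it.

Compound 1, `Cc1c(Nc2nc(N)c3c(C#N)c(N4CCC[C@H]4C)n(C)c3n2)cnn1C`: 43 nM
Compound 2, `C[C@@H]1CCCN1c1cc2c(N)ncnc2n1C`: 6390 nM
Compound 3, `C[C@@H]1CCCN1c1c(C#N)c2c(N)nc(Nc3cn(C)nc3Cl)nc2n1C`: 21 nM

All three compounds were measured in an assay on isolated protein for inhibition of Leucine-rich repeat serine/threonine-protein kinase 2 variant G2019S (Homo sapiens), read by TR-FRET and LanthaScreen, with stated times of 50 min and 30 min, in the presence of a further agent that is not named here; on this read-out lower numbers stand for stronger inhibition and higher numbers for weaker inhibition. Compound 3 stands at the lowest number of the three. The gap to compound 2, which gives 6390 nM, is very wide, and compound 2 also lacks the nitrile and the amino-pyrazole arm that the other two carry. Among the measured compounds shown here, the single step between two measured compounds that differ in one place, a 2.0-fold lower number from compound 1 to compound 3 (0.31 log units; beyond the scatter), is modest and changes both the group on the pyrazole and where it sits.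

Compound 4, `Cc1nn(C)cc1Nc1nc(N)c2c(C#N)c(N3CCC[C@H]3C)n(C)c2n1`, differs from compound 3 in one place: methyl in place of chloro on an aromatic carbon. For the measured compounds named here, no measured step swaps a methyl for a chloro at this position, so the only guide is the modest size of the one step that touches the same pyrazole ring. A small change is expected, more likely toward a somewhat higher number than toward a lower one, but not far from the scatter. Compound 4 is therefore estimated at 35 nM, within a range of 12 nM to 100 nM. The estimated step is a 1.7-fold higher number from compound 3 to compound 4 (0.22 log units; within the scatter).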

Compound 4, half-maximal inhibitory concentration: 30 nM
Compound 4: middle estimate off by 1.2-fold (0.07 log units), on the high side; the measured number falls inside the stated range.
By their numbers in this assay, from the lowest: compounds 3, 4 and 1 (each within the scatter of the next, the first and the last beyond it); then compound 2.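

In this assay, putting methyl in place of chloro on this aromatic carbon, one heavy atom for another, gives a 1.4-fold higher number from compound 3 to compound 4 (0.15 log units; within the scatter), so the measurements do not separate these two groups at this position. Moving the methyl, with 1,3-dimethyl-1H-pyrazol-4-yl in place of 1,5-dimethyl-1H-pyrazol-4-yl, gives a 1.4-fold lower number from compound 1 to compound 4 (0.16 log units; within the scatter), so this shift on its own does not separate the two compounds either, and the earlier 2.0-fold lower number from compound 1 to compound 3 (0.31 log units; beyond the scatter) can now be read as two smaller steps that each stay within the scatter, though together they pass beyond it. Nothing given here offers an explanation for how closely these groups read at this position.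

The compounds shown carry only chloro or methyl on this carbon, so it remains open what a longer chain such as propyl, a methoxy group or an amine would do there. As far as these compounds go, compound 2 differs from the other compounds in more than one place, so the separate contributions of the nitrile and the amino-pyrazole arm also remain open.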